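Trifluoromethoxy in place of trifluoromethyl: an expected small step

The compounds below may be only part of what the source reports. "The series", "measured", "known", "first", "only" and "open" are said of these compounds alone.

In a functional assay on PC-3 cells (Homo sapiens) for inhibition, read by sulforhodamine B assay (a lower number here means a stronger inhibitor of growth, a higher number a weaker inhibitor of growth), compound 1 `Oc1cccc2[nH]c(-c3ccc(-c4ccc(-c5ccccc5)cc4)cc3)nc12` gives 1240 nM, compound 2 `Oc1cccc2[nH]c(-c3ccc(-c4ccc(-c5ccc(F)cc5)cc4)cc3)nc12` gives 15300 nM and compound 3 `Oc1cccc2[nH]c(-c3ccc(-c4ccc(-c5ccc(C(F)(F)F)cc5)cc4)cc3)nc12` gives 2260 nM. Compound 3 therefore stands level with compound 1 within the scatter, as the data show a 1.8-fold higher number from compound 1 to compound 3 (0.26 log units; within the scatter), and well clear of compound 2, with a 6.8-fold lower number from compound 2 to compound 3 (0.83 log units; beyond the scatter).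

Compound 4 `Oc1cccc2[nH]c(-c3ccc(-c4ccc(-c5ccc(OC(F)(F)F)cc5)cc4)cc3)nc12` carries trifluoromethoxy in place of trifluoromethyl on an aromatic carbon, para to a large group: trifluoromethoxy in place of trifluoromethyl on an aromatic carbon. Among the compounds with values here, no measured step makes this exact change. The closest guide is compound 3, where the larger fluorinated group gave only a 1.8-fold higher number from compound 1 to compound 3 (0.26 log units; within the scatter). Compound 2 is the warning against assuming that this place is always tolerant, with a 12-fold higher number from compound 1 to compound 2 (1.09 log units; beyond the scatter), so the upper side of the range is left wider.

The step expected in this assay is a 1.2-fold higher number from compound 3 to compound 4 (0.06 log units; within the scatter), which means no expected change beyond the scatter. The estimate for compound 4 is 2600 nM, with an expected range from 900 nM to 9000 nM.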

Compound 4, concentration for 50% growth inhibition: 7410 nM
Beside the measured number, compound 4's estimate is 2.9-fold (0.45 log units) below it, and the stated range covers the measured number.
By their numbers in this assay, from the lowest: compounds 1 and 3 (each within the scatter of the next); then compound 4; then compound 2.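

In this assay the change from 4-(trifluoromethyl)phenyl to 4-(trifluoromethoxy)phenyl is not silent: it brings a 3.3-fold higher number from compound 3 to compound 4 (0.52 log units; beyond the scatter), so these two fluorinated groups are not interchangeable at this place. Against hydrogen, trifluoromethoxy gives a 6.0-fold higher number from compound 1 to compound 4 (0.78 log units; beyond the scatter), a loss that trifluoromethyl did not show beyond the scatter, while against fluoro it gives a 2.1-fold lower number from compound 2 to compound 4 (0.31 log units; beyond the scatter). The numbers here therefore do not rise with the size of the group, since fluoro stands highest of the four and trifluoromethoxy falls between trifluoromethyl and fluoro. Nothing available explains these differences.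

On these data alone, whether an amine, a carboxylic acid or a longer chain such as butoxy would be tolerated at this place remains open. So does whether methoxy, which lacks the fluorines of trifluoromethoxy, would keep or lose the number of compound 1.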